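Chloro to methyl on the shared core: compound 4

A few compounds are considered here, and "the series" means these few. Any claim that something is new, unique, unknown or untested is made for them only; others in the source may bear on it.

Going by the values given here, compound 3 `O=C1NC(=O)/C(=C/c2cn(Cc3ccccc3)c3ccc(Cl)cc23)N1` gives 29700 nM in a functional assay on A549 cells (Homo sapiens) for antiproliferative activity, read by trypan blue exclusion, with a stated time of 24 h (on this read-out higher numbers stand for weaker inhibition and lower numbers for stronger inhibition), the only number among the three measured compounds. Compound 1 `O=C1NC(=O)/C(=C/c2cn(Cc3ccccc3)c3ccccc23)N1` sits at the limit of > 40000 nM in this assay. Compound 2 `COC(=O)c1ccc(Cn2cc(/C=C3\NC(=O)NC3=O)c3ccccc32)cc1` likewise sits at the limit of > 40000 nM. The step that the two limits leave unreadable from compound 1 to compound 2 is thus unreadable. Among the compounds with values here, the step of an at least 1.3-fold lower number from compound 1 to compound 3 (0.12 log units; that floor lies within the scatter) is the one change at an aromatic carbon of the shared core that yields a number, and with two of three values at the limit of > 40000 nM in this assay, at which 2 of the 3 values shown sit, its floor lies within the scatter. Compound 4 `Cc1ccc2c(c1)c(/C=C1\NC(=O)NC1=O)cn2Cc1ccccc1` differs from compound 3 by methyl in place of chloro on an aromatic carbon. Within the data shown here, no measured step exchanges one substituent for another at that position. Compound 4 is therefore expected to stay close, estimated at 35000 nM with a range from 15000 nM to 80000 nM, and it may well turn out that the expected value lies at a limit of this assay. The step of a 1.2-fold higher number from compound 3 to compound 4 (0.07 log units; within the scatter) is expected to be small.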

Compound 4, half-maximal inhibitory concentration: 27700 nM
Compound 4: middle estimate off by 1.3-fold (0.10 log units), on the high side; low and high end bracket the measured number.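

Methyl in place of chloro at this aromatic carbon gives a 1.1-fold lower number from compound 3 to compound 4 (0.03 log units; within the scatter) in this assay, the only measured exchange of one substituent for another at this position. Methyl in place of hydrogen gives an at least 1.4-fold lower number from compound 1 to compound 4 (0.15 log units; that floor lies within the scatter), a floor that, like the one for chloro, stays inside the scatter. That step is set by a limit and not by a number: the limit of > 40000 nM in this assay, at which 2 of the 4 values shown sit.

Open, on these data alone, is whether an amine, a carboxylic acid or a longer chain at this position would move the number beyond the scatter. Also open, as far as these compounds go, is the true size of the step from hydrogen, which only a number for compound 1 could give.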